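A few compounds are considered here, and "the series" means these few. Any claim that something is new, unique, unknown or untested is made for them only; others in the source may bear on it.

Working notes on the series in a functional assay on MGC-803 cells (Homo sapiens) for inhibition, read by MTT assay, with a stated time of 48 h; on this read-out higher numbers stand for weaker inhibition and lower numbers for stronger inhibition.

Compound 1 `C/C=C/C(=O)N(Cc1ccc(OC)c(OC)c1)c1cc(OC)c(OC)c(OC)c1` gives 20100 nM in this assay. Compound 3 `COc1ccc(N(Cc2cc(OC)c(OC)c(OC)c2)C(=O)CN=[N+]=[N-])cc1O` gives 22400 nM in this assay; the two numbers lie close to one another. Compound 2 `CC/C=C/C(=O)N(Cc1ccc(OC)c(O)c1)c1cc(OC)c(OC)c(OC)c1` gives 58 nM in this assay, the lowest of the three numbers, and its gaps to compound 1 and to compound 3 both lie well beyond the usual scatter, so compound 2 is the most potent of the measured set. Within the data shown here, no step between measured compounds that differ in a single place is at hand, so the effect of changing only the acyl group has not been seen in isolation.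

Compound 4 `COc1ccc(CN(C(=O)C[Se]C#N)c2cc(OC)c(OC)c(OC)c2)cc1O` is not yet measured. It differs from compound 2 as follows: a group of 4 heavy atoms (2 carbon, 1 nitrogen, 1 selenium; no ring) in place of a group of 4 heavy atoms (4 carbon; no ring), on a carbonyl carbon. Compound 3 carries a small acyl group and gives a high number, but compound 3 differs from compound 2 in more than one place, so its value can only hint at the outcome. The step from compound 2 to compound 4 is expected to run toward weaker inhibition and to exceed the scatter, at roughly a 43-fold higher number from compound 2 to compound 4 (1.63 log units; beyond the scatter). Compound 4 is accordingly estimated at 2500 nM in this assay, within a range of 250 nM to 25000 nM.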

Compound 4, half-maximal inhibitory concentration: 270 nM
Compound 4: the middle estimate sits 9.3-fold (0.97 log units) above what was measured, within the range that was stated.
By their numbers in this assay, from the lowest: compound 2; then compound 4; then compounds 1 and 3 (each within the scatter of the next).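

Among these compounds, this gives the first step where only one place changes. On the carbonyl carbon whose other neighbour is the amide-type nitrogen, putting a selenocyanatomethyl group in place of but-1-en-1-yl gives a 4.7-fold higher number from compound 2 to compound 4 (0.67 log units; beyond the scatter) in this assay. The position therefore responds to the identity of this group even at an equal count of heavy atoms, yet the step is modest in size and compound 4 still gives 270 nM. Nothing measured on these compounds accounts for the direction or size of the step.

The compounds shown leave open which part of the exchange carries the step: the selenium, the nitrile, or the loss of the double bond of but-1-en-1-yl. A thiocyanatomethyl group, with sulfur in place of selenium, and a saturated butyl chain on the same carbonyl carbon would each separate one of these parts from the others, while the shared core stayed unchanged.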